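CXCR4 antagonists: reshaping the piperazine on the core

The source may hold more compounds than are shown below. What is called first, only, known or untested is meant among the compounds shown, and "the series" means these compounds.

Three compounds have been measured in a functional assay on CCRF-CEM cells for antagonist activity at C-X-C chemokine receptor type 4 (Homo sapiens), read by calcium flux, with stated times of 25 min and 90 s; a lower number here means a stronger inhibitor, a higher number a weaker inhibitor:

Compound 1, `CN(C[C@@H]1Cc2c(cccc2N2CCNCC2)CN1)[C@H]1CCCc2cccnc21`: 313 nM
Compound 2, `CN(C[C@H]1Cc2c(cccc2N2CCN(C3CC3)CC2)CN1)[C@H]1CCCc2cccnc21`: 23.5 nM
Compound 3, `FC1(F)CCC(CN(C[C@H]2Cc3c(cccc3N3CCNCC3)CN2)[C@H]2CCCc3cccnc32)CC1`: 498 nM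

Compound 2 gives the lowest number of the three, and its gap to compound 1, the nearest of the others, lies beyond the usual scatter, as does its gap to compound 3. It is therefore the strongest inhibitor in this set. The unmeasured compound 4, `CN(C[C@H]1Cc2c(cccc2N2CCN3CCC[C@@H]3C2)CN1)[C@H]1CCCc2cccnc21`, keeps everything in compound 2 except one change: a group of 9 heavy atoms (7 carbon, 2 nitrogen; one five-membered non-aromatic ring with 1 hetero atom, one six-membered non-aromatic ring with 2 hetero atoms) in place of a group of 9 heavy atoms (7 carbon, 2 nitrogen; one three-membered non-aromatic ring of carbon only, one six-membered non-aromatic ring with 2 hetero atoms), on an aromatic carbon. The same atoms are present in both, only joined differently, so the distal nitrogen of the six-membered ring stays substituted, as in compound 2, rather than bare as in compound 1 and compound 3. For the measured compounds named here, no measured pair shows this exact change. The expectation is a modest loss, within or a little beyond the scatter, from compound 2 to compound 4: a 2.1-fold higher number from compound 2 to compound 4 (0.33 log units; beyond the scatter). Compound 4 is estimated at 50 nM, with a range from 15 nM to 170 nM.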

Compound 4, half-maximal inhibitory concentration: 3.59 nM
Compound 4: middle estimate off by 14-fold (1.14 log units), on the high side; measured number outside the range, below it.
By their numbers in this assay, from the lowest: compound 4; then compound 2; then compounds 1 and 3 (each within the scatter of the next).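

At this aromatic carbon, the way the atoms are joined matters, not only which atoms are present: replacing the 4-cyclopropylpiperazin-1-yl group with its isomer bearing one six-membered and one five-membered non-aromatic ring gives a 6.5-fold lower number from compound 2 to compound 4 (0.82 log units; beyond the scatter) in this assay and so a stronger inhibitor. Both groups have the same heavy atoms and the same counts of hydrogen-bond donors and acceptors, so those counts alone do not settle the result at this position. Nothing shown here explains the gain.

The entering group also brings a defined stereocentre, and the compounds shown leave open how its opposite configuration would compare. They also leave open how a morpholine ring or a 4-methylpiperazin-1-yl group would fare on this same aromatic carbon.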